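Shortening the Oxime Acid Arm: Compound 1 to Compound 3

The source may report more compounds than this note shows. Statements on the series, on what has been measured and on what is new or still open speak of the compounds shown alone.

Compound 1 `CC/C(=N\OC(c1ccc(OCc2ccc3ccccc3n2)cc1)C1CCCCC1)C(=O)O` — 30 nM
Compound 2 `CC(C)(CC(O/N=C/C(=O)O)c1ccc(OCc2ccc3ccccc3n2)cc1)c1ccccc1` — 10 nM

In a functional assay for inhibition of Polyunsaturated fatty acid 5-lipoxygenase (Homo sapiens) (a lower number here means a stronger inhibitor, a higher number a weaker inhibitor), compound 1 stands at the higher of the two numbers, and compound 2 lies lower by a margin beyond the usual scatter. Compound 3 `O=C(O)/C=N/OCC(c1ccc(OCc2ccc3ccccc3n2)cc1)C1CCCCC1` differs from compound 1 by a group of 7 heavy atoms (3 carbon, 1 nitrogen, 3 oxygen; no ring) in place of a group of 8 heavy atoms (4 carbon, 1 nitrogen, 3 oxygen; no ring), on a saturated chain carbon bound to an aromatic carbon and a saturated ring carbon. Going by the values given here, no measured pair differs in just one place, so no step of this kind is known. Compound 2 also carries an aldoxime acid and gives 10 nM, which hints that such a change is tolerated. The expected step is a 1.5-fold lower number from compound 1 to compound 3 (0.18 log units; within the scatter), small and not clearly beyond the scatter. Compound 3 is estimated at 20 nM, with a range from 5 nM to 80 nM.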

Compound 3, half-maximal inhibitory concentration: 47 nM
Estimate against measurement, compound 3: 2.4-fold (0.37 log units) below; measured number inside the range.
By their numbers in this assay, from the lowest: compound 2; then compounds 1 and 3 (each within the scatter of the next).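

In this assay, going by these compounds alone, this is the first step that can be read at the saturated chain carbon bound to an aromatic carbon and a saturated ring carbon: putting the group of 7 heavy atoms in place of the group of 8 heavy atoms gives a 1.6-fold higher number from compound 1 to compound 3 (0.19 log units; within the scatter). This change therefore leaves no clear difference in inhibition. Nothing available explains this result. Going by these compounds, what a longer chain in this group, such as propyl, or an amide in place of its carboxylic acid would do remains open.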